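Swapping the amide aryl group on a shared core

The compounds below may be only part of what the source reports. "The series", "measured", "known", "first", "only" and "open" are said of these compounds alone.

Three compounds share one core and differ only in the aromatic group attached to the carbonyl carbon of the amide. Compound 1 `O=C(Nc1ccc(Cl)c(-c2nnc3c(Cl)cccn23)c1)c1ccc(F)cc1Cl` gives 75000 nM in a functional assay on MDA-MB-231 cells (Homo sapiens) for antiproliferative activity, read by MTT assay, with stated times of 72 h and 4 h; a lower number here means a stronger inhibitor, a higher number a weaker inhibitor. Compound 2 `O=C(Nc1ccc(Cl)c(-c2nnc3c(Cl)cccn23)c1)c1ccccn1` gives 92000 nM in this assay, and compound 3 `O=C(Nc1ccc(Cl)c(-c2nnc3c(Cl)cccn23)c1)c1cccnc1Cl` gives 89700 nM. Compound 3 thus holds the second highest of the three numbers, with compound 2 nearest to it and compound 1 furthest away; the steps of a 1.2-fold higher number from compound 1 to compound 3 (0.08 log units; within the scatter) and a 1.0-fold lower number from compound 2 to compound 3 (0.01 log units; within the scatter) are both small, so no ordering among the three can be claimed.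

Compound 4 `CS(=O)(=O)c1cccc(C(=O)Nc2ccc(Cl)c(-c3nnc4c(Cl)cccn34)c2)c1` carries the change (3-(methylsulfonyl)phenyl in place of 2-chloropyridin-3-yl on a carbonyl carbon). For the measured compounds named here, two measured steps touch the same place: the step of a 1.2-fold higher number from compound 1 to compound 2 (0.09 log units; within the scatter) and the step of a 1.2-fold higher number from compound 1 to compound 3 (0.08 log units; within the scatter), together with a 1.0-fold lower number from compound 2 to compound 3 (0.01 log units; within the scatter). All of them stay within the scatter, even though the groups exchanged there differ in ring atoms and substituents. Going by the values given here, no measured compound carries a methylsulfonyl group, so the new group is untested here.

On that basis the expected step of a 1.0-fold higher number from compound 3 to compound 4 (0.00 log units; within the scatter) is none beyond the scatter, and compound 4 is estimated at 90000 nM in this assay, with a range from 40000 nM to 200000 nM.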

Compound 4, half-maximal inhibitory concentration: > 100000 nM
Compound 4 ended at the assay's limit; the forecaster's own chance of this, stated with the estimate: 10%; middle value at least 1.1-fold (0.04 log units) from the limit.
By their numbers in this assay, from the lowest: compounds 1, 3 and 2 (each within the scatter of the next). At a limit, above all of these: compound 4.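

In this assay, for the compounds shown here, compound 4, which carries 3-(methylsulfonyl)phenyl on the carbonyl carbon, is the one compound that gives no measured number, only a limit of the assay: the limit of > 100000 nM in this assay, at which 1 of the 4 values shown sits. Going by these compounds alone, the new steps are therefore floors rather than sizes: an at least 1.1-fold higher number from compound 3 to compound 4 (0.04 log units; that floor lies within the scatter), an at least 1.0-fold higher number from compound 2 to compound 4 (0.03 log units; that floor lies within the scatter) and an at least 1.3-fold higher number from compound 1 to compound 4 (0.12 log units; that floor lies within the scatter), so none of them shows a real separation from the earlier compounds. What compound 4 adds is a fourth aromatic group at this place, now a ring of carbon only with a methylsulfonyl group, and this larger group does not bring the number down into a clearly lower range.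

Going by these compounds, how far the true value of compound 4 lies past the limit cannot be read, so whether the change has any real effect remains unknown. Also open, on these data alone, is whether a different kind of group on the carbonyl carbon, such as a ring bearing an amine or a carboxylic acid, or a longer alkyl chain in place of the ring, would move the number beyond the scatter.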